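Cinnamoyl for benzoyl on a threonine dodecylamide

A few compounds are considered here, and "the series" means these few. Any claim that something is new, unique, unknown or untested is made for them only; others in the source may bear on it.

Compound 1 `CCCCCCCCCCCCCCCCCCNC(=O)[C@@H](N)[C@@H](C)O` — in a functional assay on HepG2 cells (Homo sapiens) for cytotoxicity, read by MTT assay, with a stated time of 48 h (a higher number here means a weaker inhibitor, a lower number a stronger inhibitor), compound 1 gives 44500 nM.
Compound 2 `CCCCCCCCNC(=O)[C@@H](NC(=O)c1nccc2ccccc12)[C@@H](C)O` — in this assay compound 2 gives 88200 nM.
Compound 3 `CCCCCCCCCCCCNC(=O)[C@@H](NC(=O)c1ccccc1)[C@@H](C)O` — in this assay compound 3 reaches only a limit, > 400000 nM.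

Among the measured compounds shown here, compound 3 thus stands at the assay limit, as stated in the limit of > 400000 nM in this assay, at which 1 of the 3 values shown sits, and no number is known for it, so no measured step leads away from it. Compound 4 `CCCCCCCCCCCCNC(=O)[C@@H](NC(=O)/C=C/c1ccccc1)[C@@H](C)O` differs from compound 3 by one change: 2-phenylethenyl in place of phenyl on a carbonyl carbon. Without a measured step involving either compound, the expected step from compound 3 to compound 4 in this assay is estimated as an at least 1.3-fold lower number from compound 3 to compound 4 (0.12 log units; that floor lies within the scatter), most likely none beyond the scatter. Compound 4 is therefore expected at 300000 nM, within a range of 100000 nM to 700000 nM.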

Compound 4, half-maximal inhibitory concentration: > 200000 nM
Compound 4: only a limit was reported; the forecaster's own chance of this, stated with the estimate: 55%; the middle value is on the limit's open side.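

Compound 3 and compound 4 are both reported only as limits in this assay, so no step can be read between them. The compounds shown leave open whether 2-phenylethenyl in place of phenyl on a carbonyl carbon changes the number at all.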